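The compounds below may be only part of what the source reports. "The series", "measured", "known", "first", "only" and "open" are said of these compounds alone.

In a functional assay on A549 cells (Homo sapiens) for cytotoxicity, read by MTT assay, with a stated time of 72 h (on this read-out lower numbers stand for stronger inhibition and higher numbers for weaker inhibition), compound 2 `Cc1cc(=O)n(-c2ccc(F)cc2)nc1C(=O)Nc1ccc(Oc2ncnc3sccc23)cc1` gives 7050 nM, the lowest of the two numbers seen so far. Its nearest neighbour is compound 1 `Cc1cc(=O)n(-c2ccccc2C(F)(F)F)nc1C(=O)Nc1ccc(Oc2ncnc3sccc23)cc1`, which in this assay gives 19900 nM. Compound 3 `Cc1cc(=O)n(-c2ccc(F)c(F)c2)nc1C(=O)Nc1ccc(Oc2ncnc3sccc23)cc1` has not yet been measured. It differs from compound 2 by fluoro in place of hydrogen on an aromatic carbon. Among the measured compounds shown here, only one measured step bears on this change, the one in which the ring on the aromatic nitrogen was swapped, 4-fluorophenyl in place of 2-(trifluoromethyl)phenyl, and that step gave a 2.8-fold lower number from compound 1 to compound 2 (0.45 log units; beyond the scatter). Adding a single fluoro to that ring is a smaller alteration than exchanging the whole ring, so in this assay the expected step is small, in either direction or none beyond the scatter. Compound 3 is therefore estimated at 6000 nM, with a range from 2500 nM to 15000 nM. The expected step is a 1.2-fold lower number from compound 2 to compound 3 (0.07 log units; within the scatter).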

Compound 3, half-maximal inhibitory concentration: 13500 nM
For compound 3 the middle estimate is 2.3-fold (0.35 log units) below the measured one; the range from low to high includes it.
By their numbers in this assay, from the lowest: compounds 2, 3 and 1 (each within the scatter of the next, the first and the last beyond it).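

In this assay, adding a second fluoro to turn 4-fluorophenyl into 3,4-difluorophenyl gives a 1.9-fold higher number from compound 2 to compound 3 (0.28 log units; within the scatter), so at this ring carbon a fluoro brings no difference that can be told from ordinary repeat variation. Replacing the whole ring gives a 1.5-fold lower number from compound 1 to compound 3 (0.17 log units; within the scatter), so the difference seen earlier between the rings of compound 1 and compound 2 is not matched with 3,4-difluorophenyl and holds only for 4-fluorophenyl. No measurement shown here explains these numbers.

From the compounds shown here alone, it remains open whether a methoxy group, an amine or a carboxylic acid on this same ring carbon would shift the number beyond the scatter. Also open, going by these compounds, is how 3-fluorophenyl, which has a fluoro on this carbon but none in the 4-position, would behave.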